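The source may report more compounds than this note shows. Statements on the series, on what has been measured and on what is new or still open speak of the compounds shown alone.

Compound 1 `O=c1c2ccccc2[se]n1-c1nc(SCc2ccc(Cl)cc2)n[nH]1` gives 42100 nM in a functional assay on A549 cells (Homo sapiens) for antiproliferative activity, read by CCK-8 assay, with a stated time of 48 h; a lower number here means a stronger inhibitor, a higher number a weaker inhibitor.
Compound 2 `CCCSc1n[nH]c(-n2[se]c3ccccc3c2=O)n1` gives 45500 nM in this assay.
Compound 3 `Cc1cccc(CSc2n[nH]c(-n3[se]c4ccccc4c3=O)n2)c1` gives 12400 nM in this assay.

Among these three numbers compound 1 stands second highest. Its nearest neighbour is compound 2, reached by a 1.1-fold higher number from compound 1 to compound 2 (0.03 log units; within the scatter), a step within the scatter, so the two cannot be told apart. Its furthest neighbour is compound 3, reached by a 3.4-fold lower number from compound 1 to compound 3 (0.53 log units; beyond the scatter), a modest step beyond the scatter toward stronger inhibition.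

Compound 4 `CCCCCSc1n[nH]c(-n2[se]c3ccccc3c2=O)n1` is the unmeasured member. It differs from compound 1 as follows: butyl in place of 4-chlorophenyl on a saturated chain carbon bound to a sulfur. The step that bears most directly on this change is a 1.1-fold higher number from compound 1 to compound 2 (0.03 log units; within the scatter), where a short chain likewise took the place of the 4-chlorophenyl at the same saturated chain carbon bound to a sulfur, and the number stayed within the scatter. The step of a 3.7-fold lower number from compound 2 to compound 3 (0.56 log units; beyond the scatter) shows that a ring at that place can lower the number, but compound 4 carries a chain, not a ring. On this basis the expected step is a 1.1-fold higher number from compound 1 to compound 4 (0.03 log units; within the scatter), with no change beyond the scatter. For compound 4 the estimated value in this assay is 45000 nM, expected to fall between 20000 nM and 100000 nM.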

Compound 4, half-maximal inhibitory concentration: 21100 nM
For compound 4 the middle estimate is 2.1-fold (0.33 log units) above the measured one; the measured number falls inside the stated range.
By their numbers in this assay, from the lowest: compounds 3, 4, 1 and 2 (each within the scatter of the next, the first and the last beyond it).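

The chain at this place turns out to matter on its own: going from the shorter chain of compound 2 to the pentyl of compound 4 adds only an ethyl on a saturated chain carbon, three bonds along the chain from a sulfur, yet gives a modest step beyond the scatter toward stronger inhibition in this assay (a 2.2-fold lower number from compound 2 to compound 4 (0.33 log units; beyond the scatter)). Until now, only compound 3, with its 3-methylphenyl, stood apart from compound 2, but compound 4 reaches the same range with no ring in this group, since compound 3 and compound 4 cannot be told apart (a 1.7-fold higher number from compound 3 to compound 4 (0.23 log units; within the scatter)). Compound 1 and compound 4 also cannot be told apart (a 2.0-fold lower number from compound 1 to compound 4 (0.30 log units; within the scatter)), so replacing the 4-chlorobenzyl with pentyl leaves the number within the scatter, and a ring here does not by itself set the number, as compound 1 and compound 3 differ beyond the scatter.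

No evidence is available to explain why these compounds differ. Going by these compounds, it remains open whether a chain longer than pentyl would lower the number further, and what an amine or a carboxylic acid in place of the pentyl would do.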